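From phenyl to 4-hydroxyphenyl on compound 2

The source may hold more compounds than are shown below. What is called first, only, known or untested is meant among the compounds shown, and "the series" means these compounds.

Measured in a functional assay on MCF7 cells (Homo sapiens) for antiproliferative activity, read by MTT assay, with a stated time of 24 h; on this read-out lower numbers stand for stronger inhibition and higher numbers for weaker inhibition:
Compound 1 `COc1cc(/C=C/C(=O)NNC(=O)c2ccccc2)ccc1O`: 5220 nM
Compound 2 `COc1cc(/C=C/C(=O)NNC(=O)c2ccccc2)cc(OC)c1O`: > 10000 nM (a limit of the assay)

Compound 2 stands at > 10000 nM in this assay, which is a limit and not a number. Compound 3 `COc1cc(/C=C/C(=O)NNC(=O)c2ccc(O)cc2)cc(OC)c1O` carries one change, (hydroxy in place of hydrogen on an aromatic carbon), hydroxy in place of hydrogen on an aromatic carbon. For the measured compounds named here, the only measured step, an at least 1.9-fold higher number from compound 1 to compound 2 (0.28 log units; that floor lies within the scatter), concerns a methoxy rather than a hydroxy, so it bears on this change only loosely. Compound 2 itself offers only (the limit of > 10000 nM in this assay, at which 1 of the 2 values shown sits). No step beyond the scatter is therefore expected in this assay, in either direction. The expected step is an at least 1.1-fold lower number from compound 2 to compound 3 (0.04 log units; that floor lies within the scatter). For compound 3 the estimated value is 9000 nM, with an expected range of 3500 nM to 20000 nM.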

Compound 3, half-maximal inhibitory concentration: 9320 nM
The estimate for compound 3 lay 1.0-fold (0.02 log units) below the measured number; the range from low to high includes it.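

Compound 2 stands at > 10000 nM in this assay, which is a limit of the assay and not a number. Phenyl to 4-hydroxyphenyl at this position gives an at least 1.0-fold lower number from compound 2 to compound 3 (0.03 log units; that floor lies within the scatter), so a hydroxy here still allows a measurable number, compound 3 reading 9320 nM. The true size of the step cannot be read, because one end of it is a limit: the limit of > 10000 nM in this assay, at which 1 of the 3 values shown sits.

Open, on these data alone, is whether an amine or a carboxylic acid at this position would move the number. Also open, as far as these compounds go, is whether hydroxy would behave alike on the core of compound 1.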